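Fluoro for morpholinylcarbonyl on the shared core

The source may report more compounds than this note shows. Statements on the series, on what has been measured and on what is new or still open speak of the compounds shown alone.

Measured so far:
Compound 1 `Nc1cccc(-c2cnc(C(=O)CCCCCCc3ccccc3)o2)c1` — in an assay (Rattus norvegicus) for inhibition of Fatty-acid amide hydrolase 1 (Homo sapiens) (on this read-out higher numbers stand for weaker inhibition and lower numbers for stronger inhibition), compound 1 gives 19 nM.
Compound 2 `O=C(CCCCCCc1ccccc1)c1ncc(-c2ncccc2C(=O)O)o1` — in this assay compound 2 gives > 50 nM, a limit of the assay rather than a number (the limit of > 50 nM in this assay, at which 1 of the 3 values shown sits).
Compound 3 `O=C(CCCCCCc1ccccc1)c1ncc(C(=O)N2CCOCC2)o1` — in this assay compound 3 gives 24 nM.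

Of the two numbers, compound 3 gives the higher, though compound 1 lies within the scatter of it (a 1.3-fold higher number from compound 1 to compound 3 (0.10 log units; within the scatter)). Compound 4 `O=C(CCCCCCc1ccccc1)c1ncc(F)o1` carries the change (fluoro in place of (morpholin-4-yl)carbonyl on an aromatic carbon). Going by the values given here, no measured step exchanges a group for fluoro; the nearest are the exchanges at the same aromatic carbon, a 1.3-fold higher number from compound 1 to compound 3 (0.10 log units; within the scatter) and an at least 2.0-fold lower number from compound 2 to compound 3 (0.31 log units; beyond the scatter), one within the scatter and one beyond. Three different groups there have given numbers close together or a limit, so no direction beyond the scatter is expected. The estimate for compound 4 is 30 nM (range 8 nM to 120 nM), an expected step of a 1.3-fold higher number from compound 3 to compound 4 (0.10 log units; within the scatter).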

Compound 4, inhibition constant: 30 nM
The estimate for compound 4 equals the measured number at the digits printed; low and high end bracket the measured number.
By their numbers in this assay, from the lowest: compounds 1, 3 and 4 (each within the scatter of the next). At a limit, above all of these: compound 2.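

A single fluoro, one heavy atom with no ring, replaces the (morpholin-4-yl)carbonyl on this aromatic carbon with a 1.3-fold higher number from compound 3 to compound 4 (0.10 log units; within the scatter), and the exchange for 3-aminophenyl gives a 1.6-fold higher number from compound 1 to compound 4 (0.20 log units; within the scatter). Among compounds 1, 3 and 4, a large group at this position is therefore not required to keep the number in this range, while compound 2 gives an at least 1.6-fold lower number from compound 2 to compound 4 (0.22 log units; that floor lies within the scatter), which fixes no order. Compound 2 stands at a limit, not a number: the limit of > 50 nM in this assay, at which 1 of the 4 values shown sits.

Open, as far as these compounds go, is whether a hydrogen, an amine or a carboxylic acid directly on this carbon would stay in the same range. Also open, from the compounds shown here alone, is how a shorter or longer chain between the carbonyl and the phenyl would behave with fluoro in place.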